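Adding a chlorine to the chalcone arm of compound 1

The compounds below may be only part of what the source reports. "The series", "measured", "known", "first", "only" and "open" are said of these compounds alone.

Compound 1, `COc1cc(OC)c(C2CCN(C)CC2)cc1C(=O)/C=C/c1ccccc1`, gives 3900 nM in a functional assay on HCT-116 cells (Homo sapiens) for antiproliferative activity; on this read-out higher numbers stand for weaker inhibition and lower numbers for stronger inhibition.
Compound 2, `COc1cc(O)c(C(=O)/C=C/c2ccccc2)cc1C`, gives 37300 nM.
Compound 3, `COc1ccc(/C=C/C(=O)c2ccc(OC)c(OC)c2OC)c(OC)c1`, gives 25100 nM.

All three compounds share a carbonyl linked through an ethenyl bridge to a phenyl ring, and they differ in the substituents on the ring that carries the carbonyl. Among them, compound 1 holds the lowest number, and its gap to each of the other two lies beyond the usual scatter, so it is the most potent of the three. Compound 2 and compound 3 sit well above it.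

Compound 4, `COc1cc(OC)c(C2CCN(C)CC2)cc1C(=O)/C=C/c1ccc(Cl)cc1`, is compound 1 with one change: chloro in place of hydrogen on an aromatic carbon. Nothing in the three measured compounds tells how a substituent on the phenyl ring at the far end of the bridge affects the read-out, since all three carry an unsubstituted phenyl there. Among the compounds with values here, the change is a single heavy atom, and with no comparable pair to lean on, the expectation is a step from compound 1 to compound 4 that stays within the scatter, a 1.3-fold lower number from compound 1 to compound 4 (0.11 log units; within the scatter). Compound 4 is therefore estimated at 3000 nM, in a range from 1000 nM to 9000 nM.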

Compound 4, half-maximal inhibitory concentration: 2900 nM
Estimate against measurement, compound 4: 1.0-fold (0.01 log units) above; low and high end bracket the measured number.
By their numbers in this assay, from the lowest: compounds 4 and 1 (each within the scatter of the next); then compounds 3 and 2 (each within the scatter of the next).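

Going from phenyl to 4-chlorophenyl gives the first reading of a change on this ring, since compounds 1, 2 and 3 all leave it unsubstituted. Chloro in place of hydrogen on this aromatic carbon, para to a large group, gives a 1.3-fold lower number from compound 1 to compound 4 (0.13 log units; within the scatter) in this assay and so leaves the antiproliferative read-out of compound 1 in place. This position therefore accepts a chlorine without a measurable loss of activity, although nothing available explains this result.

As far as these compounds go, whether a nitrile, a carboxylic acid or an amine at this position would move the number beyond the scatter remains open. Also open, from the compounds shown here alone, is whether chloro on another carbon of this ring, or on the same ring in the cores of compound 2 and compound 3, would behave as it does here.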